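A few compounds are considered here, and "the series" means these few. Any claim that something is new, unique, unknown or untested is made for them only; others in the source may bear on it.

In a functional assay on CWR22R cells (Homo sapiens) for antiproliferative activity, read by CCK-8 assay, with a stated time of 6 days (on this read-out higher numbers stand for weaker inhibition and lower numbers for stronger inhibition), compound 1 `N#Cc1ccc(N2CCc3cc(-c4cnc5ccccc5c4)ccc3C2)cc1C(F)(F)F` gives 25900 nM. Two other compounds were measured in the same way on different cores. Compound 2 `CCN(c1ccc(C#N)c(Cl)c1)c1cc(-c2cccs2)ccc1C` gives 22000 nM in this assay, and compound 3 `N#Cc1ccc(N2CCCc3c(-c4ccncc4)cccc32)cc1C(F)(F)F` gives 15000 nM in this assay. Compound 1 stands at the top of the three numbers, but both gaps fall inside the usual scatter of repeated measurements, so none of the three can be called weaker or stronger than another; all three sit in the weak range.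

Compound 4 `N#Cc1ccc(N2CCc3cc(-c4cccnc4)ccc3C2)cc1C(F)(F)F` differs from compound 1 in a single place: pyridin-3-yl in place of quinolin-3-yl on an aromatic carbon. Among the measured compounds shown here, no pair of measured compounds shows this change on its own, so the expectation rests only on the three numbers above and on the change itself. The step of a 1.3-fold lower number from compound 1 to compound 4 (0.11 log units; within the scatter) is expected to be small, not clearly beyond the scatter in either direction. On that basis compound 4 is estimated at 20000 nM in this assay, with a likely range from 8000 nM to 50000 nM.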

Compound 4, half-maximal inhibitory concentration: 4790 nM
Estimate against measurement, compound 4: 4.2-fold (0.62 log units) above; measured number outside the range, below it.
By their numbers in this assay, from the lowest: compound 4; then compounds 3, 2 and 1 (each within the scatter of the next).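

On the shared core, this aromatic carbon proves sensitive to the group it carries: in this assay, pyridin-3-yl in place of quinolin-3-yl gives a 5.4-fold lower number from compound 1 to compound 4 (0.73 log units; beyond the scatter) and so moves the number beyond the scatter. The earlier compounds shown here could not show this, as they sit on different cores and offer no single-place comparison. The change removes the six-membered aromatic ring of carbon only and keeps the ring with one hetero atom, so in this one pair the smaller group goes with stronger inhibition, though nothing available explains the shift.

Going by these compounds, whether the ring nitrogen itself matters remains open, and a plain phenyl group at this place would test that. Also open, on these data alone, is whether an added amine or carboxylic acid on the pyridine ring would lower the number further or raise it.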